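Shortening the sulfonyl alkyl in compound 2

A few compounds are considered here, and "the series" means these few. Any claim that something is new, unique, unknown or untested is made for them only; others in the source may bear on it.

Working notes on the series. For the measured compounds named here, compound 2 `CCCS(=O)(=O)NCCCOc1nc(C2CC2)nc(NS(=O)(=O)c2ccc(C(C)C)cn2)c1Oc1ccccc1OC` gives 245 nM in a functional assay for inhibition of Endothelin-1 receptor (Rattus norvegicus) (a lower number here means tighter binding, a higher number weaker binding), the lowest of the three numbers measured so far, though within the scatter of both other compounds. Compound 1 `CCS(=O)(=O)NCCOc1nc(C2CC2)nc(NS(=O)(=O)c2ccc(C(C)C)cn2)c1Oc1ccccc1OC` gives 347 nM in this assay, and compound 3 `CCS(=O)(=O)NCCCOc1nc(C2CC2)nc(NS(=O)(=O)c2ccc(C(C)(C)C)cc2)c1Oc1ccccc1OC` gives 302 nM. Going by the values given here, the single one-place step available, a 1.4-fold lower number from compound 1 to compound 2 (0.15 log units; within the scatter), is a change in which the chain and the sulfonyl alkyl both lengthen at once. Among the compounds with values here, compound 3 and compound 2 differ in a different part of the molecule; their two values lie close together and no step is drawn between them.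

Compound 4 `CCS(=O)(=O)NCCCOc1nc(C2CC2)nc(NS(=O)(=O)c2ccc(C(C)C)cn2)c1Oc1ccccc1OC` carries hydrogen in place of methyl on a saturated chain carbon, two bonds along the chain from a sulfonyl sulfur. This runs in the reverse sense of the alkyl part of the change behind a 1.4-fold lower number from compound 1 to compound 2 (0.15 log units; within the scatter), and that step did not leave the scatter. No measurement here separates the sulfonyl alkyl length from the chain length, so the expectation rests on that single step. Compound 4 is therefore expected to land close to the value of compound 2 in this assay. The step of a 1.2-fold higher number from compound 2 to compound 4 (0.09 log units; within the scatter) is expected to stay within the scatter, with no clear direction. The estimate for compound 4 is 300 nM, with a range from 150 nM to 600 nM.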

Compound 4, dissociation constant: 105 nM
Beside the measured number, compound 4's estimate is 2.9-fold (0.46 log units) above it, and the stated range ends above it.
By their numbers in this assay, from the lowest: compound 4; then compounds 2, 3 and 1 (each within the scatter of the next).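

For the compounds shown here, with the chain on the oxygen held constant, propylsulfonyl to ethylsulfonyl gives a 2.3-fold lower number from compound 2 to compound 4 (0.37 log units; beyond the scatter) in this assay and so separates the sulfonyl alkyl from the chain for the first time. With ethylsulfonyl held constant, ((ethylsulfonyl)amino)methyl in place of (ethylsulfonyl)amino gives a 3.3-fold lower number from compound 1 to compound 4 (0.52 log units; beyond the scatter) as a second one-place change beyond the scatter, so the earlier 1.4-fold lower number from compound 1 to compound 2 (0.15 log units; within the scatter) combines a change in the chain that goes with a lower number and a lengthening of the sulfonyl alkyl that goes with a higher one. The group on the other sulfonyl sulfur also matters in this comparison: 5-isopropylpyridin-2-yl in place of 4-(tert-butyl)phenyl gives a 2.9-fold lower number from compound 3 to compound 4 (0.46 log units; beyond the scatter) with the rest of the molecule unchanged.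

The compounds shown leave open whether methylsulfonyl in place of ethylsulfonyl or a longer chain on the oxygen would extend either trend. Nothing available explains why any of these steps runs as it does.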